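A few compounds are considered here, and "the series" means these few. Any claim that something is new, unique, unknown or untested is made for them only; others in the source may bear on it.

Compound 1 `COC(=O)c1nc(Br)c2cccnc2c1N[C@H]1CC[C@H](N)CC1`: > 20000 nM
Compound 2 `N[C@H]1CC[C@H](Nc2c(C(=O)NCc3ccc(F)cc3)nc(Br)c3cccnc23)CC1`: 6000 nM
Compound 3 `N[C@H]1CC[C@H](Nc2c(C(=O)NC3CCCCC3)nc(Br)c3cccnc23)CC1`: > 10000 nM

All three were tested in a functional assay on MDA-MB-435 cells (Homo sapiens) for cytotoxicity, read by MTT assay, with a stated time of 72 h; on this read-out higher numbers stand for weaker inhibition and lower numbers for stronger inhibition. For compound 1 the value is a limit of the assay, not a number. For compound 3 the value is likewise a limit. For the measured compounds named here, compound 2 therefore gives the only real number in the set. The steps among the measured compounds all change the group on the carbonyl carbon or on the amide-type nitrogen: an at least 3.3-fold lower number from compound 1 to compound 2 (0.52 log units; beyond the scatter), a step that the two limits leave unreadable from compound 1 to compound 3 and an at least 1.6-fold higher number from compound 2 to compound 3 (0.22 log units; that floor lies within the scatter).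

Compound 4 `O=C(NCc1ccc(F)cc1)c1nc(Br)c2cccnc2c1NCCO` differs from compound 2 at a different place: 2-hydroxyethyl in place of 4-aminocyclohexyl on a nitrogen on an aromatic ring. Going by the values given here, none of the measured steps touches that nitrogen, so none of them bears on this change, and its direction cannot be read from the data. Compound 2 already sits near the limits of this assay, so any weaker result would likely be reported as a limit. Compound 4 is expected to give about 10000 nM, in a range from 3000 nM to 30000 nM. The expected step is then a 1.7-fold higher number from compound 2 to compound 4 (0.22 log units; within the scatter).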

Compound 4, half-maximal inhibitory concentration: > 20000 nM
Compound 4: only a limit was reported; the forecaster's own chance of this, stated with the estimate: 50%; at least 2.0-fold (0.30 log units) between middle value and limit.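

For the compounds shown here, this is the first measured change at the nitrogen on the aromatic ring: in this assay, putting 2-hydroxyethyl in place of 4-aminocyclohexyl gives an at least 3.3-fold higher number from compound 2 to compound 4 (0.52 log units; beyond the scatter). With the (4-fluorobenzyl)amino group on the carbonyl carbon unchanged, the cytotoxicity of compound 2 therefore depends on the group at this nitrogen as well as on the group at the carbonyl carbon. The full size of the loss stays unknown, because the value of compound 4 is a limit and not a number: the limit of > 20000 nM in this assay, at which 2 of the 4 values shown sit.

Going by these compounds, the two groups differ in both the ring and the amine, so it remains open which of these parts matters. A 2-aminoethyl chain, which keeps the amine without the ring, or a 4-hydroxycyclohexyl group, which keeps the ring without the amine, would help separate the two.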